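A few compounds are considered here, and "the series" means these few. Any claim that something is new, unique, unknown or untested is made for them only; others in the source may bear on it.

Measured compounds and their values in this assay:
compound 1 `CC(C)=CCC1Cc2c(OCCCNS(=O)(=O)c3ccc(Cl)cc3)cc(=O)n(CCCO)c2CC1(C)C`: 9.8%
compound 2 `CC(C)=CCC1Cc2c(OCCCNS(=O)(=O)c3ccc(Br)cc3)cc(=O)n(CCCO)c2CC1(C)C`: 3.7%
compound 3 `CC(C)=CCC1Cc2c(OCCCNS(=O)(=O)c3ccc([N+](=O)[O-])cc3)cc(=O)n(CCCO)c2CC1(C)C`: 17.3%

In a functional assay on PANC-1 cells (Homo sapiens) for inhibition, read by MTT assay, with a stated time of 24 h, tested at 10 uM (on this read-out lower numbers stand for less inhibition and higher numbers for more inhibition at the one concentration tested (going by the name of the read-out)), compound 3 stands highest of the three numbers, although the gap to compound 1 is small, a number 7.5 percentage points higher from compound 1 to compound 3 (within the scatter), and only the gap to compound 2 is clear, a number 13.6 percentage points higher from compound 2 to compound 3 (beyond the scatter). Compound 4 `CC(C)=CCC1Cc2c(OCCCNC(=O)c3cccs3)cc(=O)n(CCCO)c2CC1(C)C` differs from compound 3 in one place: (thiophen-2-yl)carbonyl in place of (4-nitrophenyl)sulfonyl on an amine nitrogen. Among the measured compounds shown here, none of the measured steps swaps the whole group on the amine nitrogen; they only exchange one substituent on the aromatic ring, and every such step stayed small or modest, with all three compounds inhibiting weakly. A step of similar size is therefore expected here, most likely downward, a number 9.3 percentage points lower from compound 3 to compound 4 (within the scatter), and compound 4 is estimated at 8%, between 0% and 20%.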

Compound 4, a percentage reported as inhibition, at one concentration (the size of the read-out at that concentration, not a potency): 5.6%
Compound 4: the middle estimate sits 2.4 percentage points above what was measured; measured number inside the range.
By their numbers in this assay, from the lowest: compounds 2, 4, 1 and 3 (each within the scatter of the next, the first and the last beyond it).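

Replacing the whole group on the amine nitrogen, rather than one ring substituent, gives a clear drop in this assay only against the nitro compound: a number 11.7 percentage points lower from compound 3 to compound 4 (beyond the scatter). The other two steps, a number 1.9 percentage points higher from compound 2 to compound 4 (within the scatter) and a number 4.2 percentage points lower from compound 1 to compound 4 (within the scatter), show that the (thiophen-2-yl)carbonyl group cannot be told apart from the bromo and chloro sulfonyl groups here. No supporting data bear on the reason for this result. Still open, on these data alone, is whether a benzoyl group or a thiophene-2-sulfonyl group would separate the effect of the ring from that of the carbonyl or sulfonyl link.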